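The compounds below may be only part of what the source reports. "The series", "measured", "known", "first", "only" and "open" are said of these compounds alone.

Measured compounds:
compound 1, `CCCCCCc1cc2cn(COCCO)c(=O)nc2o1`, gives a limit of > 200000 nM in a functional assay on HEL cells (Homo sapiens); a lower number here means that less compound is tolerated, a higher number that more compound is tolerated.
compound 2, `CCCCCC#Cc1cc2cn(COCCO)c(=O)nc2o1`, gives a limit of > 50000 nM in this assay.
compound 3, `CCCCc1cc2cn(COCCO)c(O)nc-2n1`, gives a limit of > 200000 nM in this assay.

Going by the values given here, compound 1 stands only at a limit in this assay, and the two other values are limits as well, so no compound among the three is placed at a number. Among the compounds with values here, the one step between measured compounds, a step that the two limits leave unreadable from compound 1 to compound 2, cannot be read, because both ends sit at a limit: compound 1 at the limit of > 200000 nM in this assay, at which 2 of the 3 values shown sit, and compound 2 at the limit of > 50000 nM in this assay, at which 1 of the 3 values shown sits.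

Compound 4, `CCCCCCCCCCCc1cc2cn(COCCO)c(=O)nc2o1`, is not yet measured. It differs from compound 1 by pentyl in place of hydrogen on a saturated chain carbon, six bonds along the chain from an aromatic carbon. Within the data shown here, no measured step concerns a lengthening of the chain on the core, so nothing among the three compounds sets the size of the step, and the account must rest on the position of compound 1 alone.

Compound 4 is therefore expected to remain near the limit where compound 1 sits, with the step of an at least 2.0-fold lower number from compound 1 to compound 4 (0.30 log units; that floor lies within the scatter) estimated as small. The half-maximal cytotoxic concentration of compound 4 is estimated at 100000 nM, in a range from 20000 nM to 400000 nM, with a fair chance that this assay again reports only a limit.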

Compound 4, half-maximal cytotoxic concentration: 132000 nM
Beside the measured number, compound 4's estimate is 1.3-fold (0.12 log units) below it; the measured number falls inside the stated range.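

In this assay compound 4 gives 132000 nM, the first value among the compounds shown that is a number and not a limit, so a chain lengthened at this place on the core now has a measured cytotoxic concentration. Compound 1 remains only a limit: the limit of > 200000 nM in this assay, at which 2 of the 4 values shown sit. Pentyl in place of hydrogen on this saturated chain carbon gives an at least 1.5-fold lower number from compound 1 to compound 4 (0.18 log units; that floor lies within the scatter), so the size of the change is known only as a floor, and the true step may be larger, although the floor itself does not clear the usual scatter.

The step from hexyl to hept-1-yn-1-yl still cannot be read, since both of its ends are limits, and compound 2 therefore says nothing yet about how the alkyne compares with the saturated chains. The compounds shown also leave open how the value changes along the way from hexyl to the chain of compound 4, for example with an octyl chain, and whether a still longer chain or a carboxylic acid on the chain would bring the number down further.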